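This account rests on a few compounds, and the source may have more. Where it says the series, first, only, none or still open, it means among the compounds named here.

Measured in a functional assay on HCC 2998 cells (Homo sapiens) for inhibition, read by sulforhodamine B assay, with a stated time of 48 h; on this read-out higher numbers stand for weaker inhibition of growth and lower numbers for stronger inhibition of growth:
Compound 1 `COc1cc(-c2nn(-c3cccc(NC(=O)c4cccc(C(F)(F)F)c4)c3)cc2-c2ccncc2)ccc1Cl`: 2240 nM
Compound 2 `COc1cc(-c2nn(-c3cccc(NC(=O)Nc4ccc(Cl)c(Cl)c4)c3)cc2-c2ccncc2)ccc1Cl`: 1560 nM
Compound 3 `COc1cc(-c2nn(-c3cccc(NC(=O)Nc4cccc(C(F)(F)F)c4)c3)cc2-c2ccncc2)ccc1Cl`: 1190 nM

Compound 3 gives the lowest of these three numbers, yet its steps from compound 2 a 1.3-fold lower number from compound 2 to compound 3 (0.12 log units; within the scatter) and from compound 1 a 1.9-fold lower number from compound 1 to compound 3 (0.27 log units; within the scatter) both lie within the scatter, so no order among the three can be claimed. Compound 4 `COc1cc(-c2nn(-c3cccc(NC(=O)c4ccc(Cl)c(C(F)(F)F)c4)c3)cc2-c2ccncc2)ccc1Cl` differs from compound 3 by 4-chloro-3-(trifluoromethyl)phenyl in place of (3-(trifluoromethyl)phenyl)amino on a carbonyl carbon: the urea-type link of compound 3 becomes an amide, and the entering ring carries chlorine as well as trifluoromethyl. The step that bears most on this is the reverse of a 1.9-fold lower number from compound 1 to compound 3 (0.27 log units; within the scatter), where the same exchange of amide for urea moved the number by less than the scatter. A small step toward higher numbers in this assay is therefore expected, a 1.5-fold higher number from compound 3 to compound 4 (0.18 log units; within the scatter), though not one beyond the scatter. Compound 4 is estimated at 1800 nM, with a range of 800 nM to 4000 nM.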

Compound 4, concentration for 50% growth inhibition: 7860 nM
The estimate for compound 4 lay 4.4-fold (0.64 log units) below the measured number; measured number outside the range, above it.
By their numbers in this assay, from the lowest: compounds 3, 2 and 1 (each within the scatter of the next); then compound 4.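

In this assay, for the compounds shown here, a single chloro in place of hydrogen on an aromatic carbon gives a 3.5-fold higher number from compound 1 to compound 4 (0.55 log units; beyond the scatter) and so moves the number beyond the scatter, which no step among the earlier compounds did. The larger exchanges on the carbonyl carbon point the same way, with a 6.6-fold higher number from compound 3 to compound 4 (0.82 log units; beyond the scatter) and a 5.0-fold higher number from compound 2 to compound 4 (0.70 log units; beyond the scatter) as well. Nothing measured here explains this loss of growth inhibition.

Going by these compounds, whether a fluoro or an amine in place of that chloro would also raise the number remains open.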